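Removing the allyl group from a bis-benzylidene diketopiperazine core

A few compounds are considered here, and "the series" means these few. Any claim that something is new, unique, unknown or untested is made for them only; others in the source may bear on it.

Measured compounds:
Compound 1 `COc1ccccc1/C=c1/[nH]c(=O)/c(=C\c2ccccc2OC)n(C)c1=O` gives 2200 nM in a functional assay on K562 cells (Homo sapiens) for cytotoxicity, read by CCK-8 assay, with a stated time of 72 h; a higher number here means a weaker inhibitor, a lower number a stronger inhibitor.
Compound 2 `COc1ccccc1/C=c1/[nH]c(=O)/c(=C\c2cccc(Cl)c2Cl)[nH]c1=O` is reported in this assay as "not active" (no number reported).
Compound 3 `C=CCn1c(=O)/c(=C\c2ccccc2OC)[nH]c(=O)/c1=C\c1ccccc1OC` gives 7400 nM in this assay.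

Compound 3 thus holds the highest number among the two that were measured, with compound 1 the nearer entry. Compound 4 `COc1ccccc1/C=c1/[nH]c(=O)/c(=C\c2ccccc2OC)[nH]c1=O` differs from compound 3 by hydrogen in place of allyl on an aromatic nitrogen. Going by the values given here, the only step that bears on this change is a 3.4-fold higher number from compound 1 to compound 3 (0.53 log units; beyond the scatter), where lengthening the chain on that nitrogen weakened inhibition. Taking the chain away altogether is expected to reverse that direction and bring compound 4 back near compound 1, as a 3.0-fold lower number from compound 3 to compound 4 (0.47 log units; beyond the scatter). Compound 4 is therefore estimated at 2500 nM, within 800 nM to 8000 nM.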

Compound 4, half-maximal inhibitory concentration: "not active" (no number reported)
For compound 4 the study gives words and no number; the estimate stays without a comparison.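

Compound 4 is reported as not active in this assay without a number, so no step from compound 3 to compound 4 can be read, and no supporting data explain this result. The compounds shown leave open how large the effect of removing the allyl group is.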